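The source may hold more compounds than are shown below. What is called first, only, known or untested is meant among the compounds shown, and "the series" means these compounds.

Measured in an in vitro ADME assay on microsomes (Rattus norvegicus) for metabolic stability; a lower number here means that the compound disappears faster, a higher number that the compound lasts longer:
- compound 1 `CCc1nc(NC(CC)CC)c(OC)nc1-c1ccc(OC(F)F)cc1Cl`: 0.783 h
- compound 2 `CCc1nc(N(CC2CC2)CC2CC2)c(CC)nc1-c1ccc(Cl)cc1Cl`: < 0.0167 h (a limit)
- compound 3 `CCc1nc(-c2ccc(Cl)cc2Cl)c(CC)nc1CC(CC)CC`: 0.0417 h

Compound 3 at 0.0417 h holds the lower of the two actual numbers, and compound 1 gives 0.783 h. Compound 4 `CCCN(CCN(C)C)c1nc(CC)c(-c2ccc(Cl)cc2Cl)nc1CC` carries (2-(dimethylamino)ethyl)(propyl)amino in place of 2-ethylbutyl on an aromatic carbon. Within the data shown here, the one measured step that bears on this is an at least 2.4-fold higher number from compound 2 to compound 3 (0.39 log units; beyond the scatter), where 2-ethylbutyl replaced bis(cyclopropylmethyl)amino. Its size is open at one end (the limit of < 0.0167 h in this assay, at which 1 of the 3 values shown sits). Compound 4 reverses that kind of exchange, though with a different amino group, so a modest fall in this assay is expected on the strength of an at least 2.4-fold higher number from compound 2 to compound 3 (0.39 log units; beyond the scatter). The expected step is a 2.1-fold lower number from compound 3 to compound 4 (0.32 log units; beyond the scatter). For compound 4 the estimate is 0.02 h, with an expected range of 0.008 h to 0.06 h.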

Compound 4, half-life: < 0.0167 h
Compound 4 gave a limit, no number; the forecaster's own chance of this, stated with the estimate: 50%; middle value at least 1.1-fold (0.07 log units) from the limit.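

On the aromatic carbon para to the 2,4-dichlorophenyl group, the loss against 2-ethylbutyl in this assay is not confined to bis(cyclopropylmethyl)amino: (2-(dimethylamino)ethyl)(propyl)amino gives an at least 2.4-fold lower number from compound 3 to compound 4 (0.39 log units; beyond the scatter) as well. Compound 4 at < 0.0167 h is a limit, not a number, so this step is open at one end: the limit of < 0.0167 h in this assay, at which 2 of the 4 values shown sit. The step between the two amino compounds, compound 2 and compound 4, cannot be read.

From the compounds shown here alone, compound 1 gives 0.783 h but differs from these compounds in more than one place, so the part played by its amino group stays open. Going by these compounds, how a morpholine or a carboxylic acid would fare on this carbon also stays open.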